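Sulfonamide Chain Extension on Two Pyrimidinone Cores

The source may report more compounds than this note shows. Statements on the series, on what has been measured and on what is new or still open speak of the compounds shown alone.

Measured so far:
compound 1 `CC[C@@H]1C(=O)N(C)c2cnc(Nc3ccc(S(=O)(=O)NCCCO)cc3)nc2N1C1CCCC1` gives 262 nM
compound 2 `CC[C@@H]1C(=O)N(C)c2cnc(Nc3ccc(S(N)(=O)=O)cc3)nc2N1C1CCCC1` gives 1300 nM
compound 3 `CCC1C(=O)N(C)c2cnc(Nc3ccc(S(N)(=O)=O)cc3)nc2N1c1ccn(C)n1` is reported as "not active" (no number reported)

In a functional assay on Huh-7 cells (Homo sapiens) for antiproliferative activity, read by CCK-8 assay, with a stated time of 72 h (on this read-out lower numbers stand for stronger inhibition of growth and higher numbers for weaker inhibition of growth), the step of a 5.0-fold lower number from compound 2 to compound 1 (0.70 log units; beyond the scatter) came from one change, (3-hydroxypropyl in place of hydrogen on a sulfonamide nitrogen). Compound 4 `CCC1C(=O)N(C)c2cnc(Nc3ccc(S(=O)(=O)NCCCO)cc3)nc2N1c1ccn(C)n1` carries the same change on the core of compound 3: 3-hydroxypropyl in place of hydrogen on a sulfonamide nitrogen. The place is the same in both pairs, so this is the same change. The difference between the two cores is not broken down here. Compound 3 is reported without a number in this assay, so the step to compound 4 cannot be placed against a measured start. The earlier pair suggests a modest gain is plausible, yet a weak starting point leaves much uncertainty. For compound 4 the value in this assay is estimated at 8000 nM, expected to fall between 2000 nM and 30000 nM.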

Compound 4, concentration for 50% growth inhibition: "not active" (no number reported)
The entry for compound 4 holds no number, so the estimate cannot be set against anything.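

Compound 3 and compound 4 are both reported without a number, so no step can be read between them. Whether 3-hydroxypropyl changes growth inhibition on this core stays open, and nothing shown bears on the result.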